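Amide nitrogen substitution and whole-animal inhibition

This account rests on a few compounds, and the source may have more. Where it says the series, first, only, none or still open, it means among the compounds named here.

Compound 1 `CN(C)C(=O)/C=C1\CCc2ccc(F)cc21` gives 100% in a functional assay on the whole organism with Mus musculus as the target, at a dose of 100 mg/kg by the intraperitoneal route; on this read-out lower numbers stand for less inhibition and higher numbers for more inhibition at the one dose given (going by the name of the read-out). Compound 2 `CCN(C)C(=O)/C=C1\CCc2ccc(F)cc21` gives 100%, and the step of no change at the digits printed from compound 1 to compound 2 (within the scatter) leaves the read-out where it was. Compound 2 therefore stands level with compound 1 in this assay. Compound 3 `O=C(/C=C1\CCc2ccc(F)cc21)NC1CC1` differs from compound 2 in that (cyclopropylamino in place of ethyl(methyl)amino on a carbonyl carbon). Within the data shown here, the only measured step, a methyl added on the chain carbon at the amide-type nitrogen, was no change at the digits printed from compound 1 to compound 2 (within the scatter) and does not involve the hydrogen-bond donor that enters here, so it bears only loosely on this change. With both measured amides level in this assay, the expected step of a number 15 percentage points lower from compound 2 to compound 3 (beyond the scatter) is a modest one downward. Compound 3 is expected at 85%, between 50% and 100%.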

Compound 3, a percentage reported as inhibition, in the whole organism at one dose (the size of the read-out at that dose, not a potency): 100%
Compound 3: the middle estimate sits 15 percentage points below what was measured, and the stated range covers the measured number.
By their numbers in this assay, from the lowest: compounds 1, 2 and 3 (each within the scatter of the next).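

In this assay cyclopropylamino on the carbonyl carbon gives no change at the digits printed from compound 2 to compound 3 (within the scatter) and no change at the digits printed from compound 1 to compound 3 (within the scatter). This position therefore accepts the amide hydrogen, absent from the dimethylamino and ethyl(methyl)amino compounds, together with a three-membered ring of carbon, and the read-out stays the same. Nothing available speaks to the reason for this. Going by these compounds, at this single dose the three amides cannot be separated, so their order at lower doses remains open. Also open, on these data alone, is how an unsubstituted primary amide or a carboxylic acid would read here.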